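Trading a trifluoromethylphenyl group for a methylphenyl group

A few compounds are considered here, and "the series" means these few. Any claim that something is new, unique, unknown or untested is made for them only; others in the source may bear on it.

In an in vitro ADME assay on microsomes from liver (Mus musculus) for pharmacokinetics, read by LC-MS, with a stated time of 10 min, tested at 1 uM (a lower number here means slower removal, a higher number faster removal of the compound), compound 3 `CN1C[C@H](C(=O)Nc2ccc(C(F)(F)F)cc2)[C@@H](c2ccc(/C=C/C(=O)Nc3ccccc3N)cc2)C1` gives 23 mL/min/kg as its clearance. Compound 1 `CN1C[C@H](C(=O)Nc2ccc(F)cc2)[C@@H](c2ccc(/C=C/C(=O)Nc3ccccc3N)cc2)C1` gives 34 mL/min/kg and compound 2 `Cc1ccc(NC(=O)[C@H]2CN(C)C[C@@H]2c2ccc(/C=C/C(=O)Nc3ccccc3N)cc2)cc1` gives 62 mL/min/kg on the same scale. Measured steps of a 1.5-fold lower number from compound 1 to compound 3 (0.17 log units; within the scatter) and a 2.7-fold lower number from compound 2 to compound 3 (0.43 log units; beyond the scatter) lead to that first value, and only the second stands clear of the scatter.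

Compound 4 `Cc1cccc(NC(=O)[C@H]2CN(C)C[C@@H]2c2ccc(/C=C/C(=O)Nc3ccccc3N)cc2)c1` has not been measured yet. Its difference from compound 3 reads 3-methylphenyl in place of 4-(trifluoromethyl)phenyl on an amide-type nitrogen and in short 3-methylphenyl stands in place of 4-(trifluoromethyl)phenyl on an amide-type nitrogen, with the shared core untouched.

The closest evidence is the second step read in reverse, a trade between trifluoromethyl and methyl on an aromatic carbon. The expectation therefore rests on compound 2 at 62 mL/min/kg as the nearest measured methyl example. Among the compounds with values here, no measured step covers a 3-methylphenyl group itself, so the size of the move stays uncertain. A rise of similar size is expected, and the estimated move is a 2.2-fold higher number from compound 3 to compound 4 (0.34 log units; beyond the scatter) in this small series. Compound 4 is estimated at 50 mL/min/kg within an expected range of 27 mL/min/kg to 90 mL/min/kg for its clearance.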

Compound 4, clearance: 74 mL/min/kg
Compound 4: the middle estimate sits 1.5-fold (0.17 log units) below what was measured, within the range that was stated.
By their numbers in this assay, from the lowest: compounds 3, 1, 2 and 4 (each within the scatter of the next, the first and the last beyond it).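

In this assay, replacing 4-(trifluoromethyl)phenyl with 3-methylphenyl on the amide-type nitrogen gives a step clear of the scatter (a 3.2-fold higher number from compound 3 to compound 4 (0.51 log units; beyond the scatter)). The 3-methylphenyl group also stands clear of the 4-fluorophenyl compound (a 2.2-fold higher number from compound 1 to compound 4 (0.34 log units; beyond the scatter)), which the 4-methylphenyl group did not do (a 1.8-fold higher number from compound 1 to compound 2 (0.26 log units; within the scatter)). Moving the methyl gives no readable difference (a 1.2-fold higher number from compound 2 to compound 4 (0.08 log units; within the scatter)), so compound 2 and compound 4 cannot be told apart here, and the change from compound 3 seems to go with trading trifluoromethyl for methyl rather than with which of the two methylphenyl groups is present.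

Still open, as far as these compounds go, is how a phenyl ring carrying a methoxy group, a nitrile or an amine would behave on this nitrogen, and whether a trifluoromethyl group placed as the methyl is in 3-methylphenyl would keep the number of compound 3 or lose it. Why the clearance differs among these compounds also stays open, since nothing measured here speaks to it.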